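This account rests on a few compounds, and the source may have more. Where it says the series, first, only, none or still open, it means among the compounds named here.

Measured so far:
Compound 1 `COc1nc(CC(O)(CO)CO)c(C)c(OC)n1`: > 100000 nM
Compound 2 `COc1nc(CC(O)(COC(C)=O)COC(C)=O)c(C)c(OC)n1`: > 100000 nM

In a functional assay on HepG2 cells (Homo sapiens) for antiproliferative activity, read by MTT assay, with a stated time of 72 h (on this read-out lower numbers stand for stronger inhibition and higher numbers for weaker inhibition), compound 1 reaches only > 100000 nM, which is a limit of the assay and not a number. In this assay compound 2 likewise stops at > 100000 nM, again a limit rather than a number. Compound 2 therefore stands at the limit of > 100000 nM in this assay, at which 2 of the 2 values shown sit.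

Compound 3 `COc1nc(CC(F)(COC(C)=O)COC(C)=O)c(C)c(OC)n1` carries fluoro in place of hydroxy on a saturated chain carbon bound to three saturated chain carbons. For the measured compounds named here, no step between measured compounds is available for comparison. The expected step is a step that the limit leaves unreadable from compound 2 to compound 3, nothing beyond the scatter. Compound 3 is accordingly estimated at 150000 nM, within 30000 nM to 1000000 nM, most likely again reported only as a limit.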

Compound 3, half-maximal inhibitory concentration: > 100000 nM
Compound 3 gave a limit, no number; the forecaster's own chance of this, stated with the estimate: 85%; the middle value is on the limit's open side.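

No step can be read from compound 2 to compound 3 in this assay, as neither gives a number: the limit of > 100000 nM in this assay, at which 3 of the 3 values shown sit.

The compounds shown leave open whether fluoro in place of hydroxy changes antiproliferative activity at all.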